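The source may report more compounds than this note shows. Statements on the series, on what has been measured and on what is new or still open speak of the compounds shown alone.

Values in a functional assay on A549 cells (Homo sapiens) for cytotoxicity, with a stated time of 48 h; on this read-out higher numbers stand for weaker inhibition and lower numbers for stronger inhibition:
- compound 1 `CCOc1ccc2oc(/C=C/[S+](C)[O-])cc(=O)c2c1` gives 1500 nM
- compound 2 `CC(C)CCOc1ccc2oc(/C=C/[S+](C)[O-])cc(=O)c2c1` gives 1000 nM

These two values lie within the usual scatter of each other, so compound 2 stands level with compound 1 and neither can be ranked above the other.

Compound 3 `CCCOc1ccc2oc(/C=C/[S+](C)[O-])cc(=O)c2c1` has not yet been measured. Its difference from compound 2 is methyl in place of isopropyl on a saturated chain carbon, two bonds along the chain from an oxygen on an aromatic ring. In words, this is methyl in place of isopropyl on a saturated chain carbon, two bonds along the chain from an oxygen on an aromatic ring, which turns isopentyloxy into propoxy.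

Going by the values given here, only one measured step bears on this change. It sits at the same carbon, where isopropyl replaces hydrogen, and it is a 1.5-fold lower number from compound 1 to compound 2 (0.18 log units; within the scatter). Compound 3 carries methyl at that carbon, and with so small a step from hydrogen to isopropyl, no shift beyond the scatter is expected in this assay. With a single step to go on, this expectation is loose.

The expected change is a 1.2-fold higher number from compound 2 to compound 3 (0.08 log units; within the scatter), which would stay within the scatter. For compound 3 the estimated value is 1200 nM, with an expected range of 600 nM to 2400 nM.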

Compound 3, half-maximal inhibitory concentration: 1100 nM
For compound 3 the middle estimate is 1.1-fold (0.04 log units) above the measured one, within the range that was stated.
By their numbers in this assay, from the lowest: compounds 2, 3 and 1 (each within the scatter of the next).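

In this assay, putting methyl in place of isopropyl on this saturated chain carbon gives a 1.1-fold higher number from compound 2 to compound 3 (0.04 log units; within the scatter) and putting methyl in place of hydrogen at the same carbon gives a 1.4-fold lower number from compound 1 to compound 3 (0.13 log units; within the scatter) in a second comparison. The earlier pair covered only hydrogen and isopropyl, so methyl adds a third group of intermediate size, counted as 1 heavy atom against the 3 of isopropyl. All three compounds stand level in this cytotoxicity read-out, so across these groups the size of the substituent at this carbon shows no measurable link to the value, and no other data are available to explain that flat result.

As far as these compounds go, whether an amine, a carboxylic acid or a phenyl ring at this carbon would move the number beyond the usual scatter remains open, since hydrogen, methyl and isopropyl are all plain saturated carbon and hydrogen groups. All three compounds also share the rest of the core, so the effect of any change elsewhere in the molecule, such as at the sulfur-bearing side chain, is also still unknown.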